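A few compounds are considered here, and "the series" means these few. Any claim that something is new, unique, unknown or untested is made for them only; others in the source may bear on it.

In a functional assay on HepG2 cells (Homo sapiens) for antiproliferative activity, read by MTT assay, with a stated time of 72 h (a higher number here means a weaker inhibitor, a lower number a stronger inhibitor), compound 3 (`CCOC(=O)c1csc2nc(CN3CCN(C)CC3)c(-c3ccc(Br)cc3)n12`) gives 82700 nM. That sits within the scatter of compound 1 (`CCOC(=O)c1csc2nc(CN3CCN(Cc4ccccc4)CC3)c(-c3ccc(C)cc3)n12`) at 88200 nM, while compound 2 (`CCOC(=O)c1csc2nc(CN3CCN(Cc4ccccc4)CC3)c(-c3ccc(OC)cc3)n12`) at 26400 nM lies lower, beyond the scatter. Compound 4 (`CCOC(=O)c1csc2nc(CN3CCN(Cc4ccccc4)CC3)c(-c3ccc(Br)cc3)n12`) differs from compound 3 by phenyl in place of hydrogen on a saturated chain carbon bound to an amine nitrogen in a ring, which turns methyl to benzyl. Among the compounds with values here, the one measured step, a 3.3-fold lower number from compound 1 to compound 2 (0.52 log units; beyond the scatter), is modest and sits elsewhere, as methoxy in place of methyl on an aromatic carbon, so it bears only indirectly. Compound 1 at 88200 nM and compound 2 at 26400 nM both carry the benzyl, so only a small move toward a lower number is expected, not one beyond the scatter. The expected change is a 1.7-fold lower number from compound 3 to compound 4 (0.22 log units; within the scatter). Compound 4 is estimated at 50000 nM, within a range of 15000 nM to 110000 nM.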

Compound 4, half-maximal inhibitory concentration: 47300 nM
The estimate for compound 4 lay 1.1-fold (0.02 log units) above the measured number; the measured number falls inside the stated range.
By their numbers in this assay, from the lowest: compounds 2, 4, 3 and 1 (each within the scatter of the next, the first and the last beyond it).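

In this assay, methyl to benzyl with the bromo kept gives a 1.7-fold lower number from compound 3 to compound 4 (0.24 log units; within the scatter) and so stays within the scatter at this position. With the benzyl held, bromo in place of methoxy gives a 1.8-fold higher number from compound 2 to compound 4 (0.25 log units; within the scatter) and bromo in place of methyl gives a 1.9-fold lower number from compound 1 to compound 4 (0.27 log units; within the scatter), so compound 4 lies within the scatter of both, although compound 1 and compound 2 lie beyond it from each other. No evidence bears on the cause of these steps. On these data alone, whether an amine, a carboxylic acid or a longer chain in place of the benzyl would give a step beyond the scatter stays open. So does what chloro or nitrile would give on the aromatic carbon.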